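The source may report more compounds than this note shows. Statements on the series, on what has been measured and on what is new or still open speak of the compounds shown alone.

Measured so far:
- compound 1 `O=C1O/C(=C\Cn2cc(I)c(=O)[nH]c2=O)C(OCc2ccccc2)=C1OCc1ccccc1`: 30000 nM
- compound 2 `O=C1O/C(=C\Cn2cc(Br)c(=O)[nH]c2=O)C(OCc2ccccc2)=C1OCc1ccccc1`: 30000 nM

Among the compounds with values here, in a functional assay on HeLa cells (Homo sapiens) for inhibition (on this read-out lower numbers stand for stronger inhibition and higher numbers for weaker inhibition), compound 2 gives 30000 nM, level with compound 1, its only measured neighbour. Next comes compound 3 `O=C1O/C(=C\Cn2cc(F)c(=O)[nH]c2=O)C(OCc2ccccc2)=C1OCc1ccccc1`, with fluoro in place of bromo on an aromatic carbon. Within the data shown here, only one measured step bears on this, the swap of bromo for iodo, no change at the digits printed from compound 1 to compound 2 (within the scatter). Among the measured compounds shown here, that single step is thin evidence, and no fluoro compound has been measured yet. No change beyond the scatter is therefore expected, though the range is kept wider towards stronger inhibition. The expected step is a 1.2-fold lower number from compound 2 to compound 3 (0.08 log units; within the scatter). For compound 3 the estimated value is 25000 nM, with an expected range of 5000 nM to 40000 nM.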

Compound 3, half-maximal inhibitory concentration: 40000 nM
Beside the measured number, compound 3's estimate is 1.6-fold (0.20 log units) below it; measured number inside the range.
By their numbers in this assay, from the lowest: compounds 1, 2 and 3 (each within the scatter of the next).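

Fluoro on this aromatic carbon gives a 1.3-fold higher number from compound 2 to compound 3 (0.12 log units; within the scatter) against bromo and a 1.3-fold higher number from compound 1 to compound 3 (0.12 log units; within the scatter) against iodo in this assay as the read-out. The comparison now covers iodo, bromo and fluoro, and compound 1, compound 2 and compound 3 cannot be told apart, so the choice among these halogens does not separate them here. No supporting data bear on this flat result.

As far as these compounds go, whether a non-halogen group at this place, such as an amine or a carboxylic acid, would shift the number stays open. So does the effect of replacing the benzyl groups elsewhere on the shared core.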